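Swapping one aromatic group at the assay limit

The source may hold more compounds than are shown below. What is called first, only, known or untested is meant among the compounds shown, and "the series" means these compounds.

Compound 1 (`COc1ccc([C@H]2CC(=O)N(c3ccccc3)C2)cc1OC1CCCC1`), compound 2 (`COc1ccc([C@H]2CC(=O)N(c3cccc(O)c3)C2)cc1OC1CCCC1`) and compound 3 (`COc1ccc([C@H]2CC(=O)N(c3cc(N)cc(F)c3)C2)cc1OC1CCCC1`) share one core and differ only in the aromatic group on the amide-type nitrogen. In a functional assay on HEK293 cells (Homo sapiens) for cytotoxicity (on this read-out lower numbers stand for higher toxicity in this test and higher numbers for lower toxicity in this test), compound 1 gives > 10000 nM as a limit and not a number. Compound 2 gives > 10000 nM as a limit too. Compound 3 gives > 10000 nM as a limit as well, so it has no number of its own. With the limit of > 10000 nM in this assay, at which 3 of the 3 values shown sit, no ranking of the three is possible.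

Among the compounds with values here, compound 4 (`COc1ccc([C@H]2CC(=O)N(c3ccccc3C#N)C2)cc1OC1CCCC1`) keeps the shared core but carries 2-cyanophenyl in place of 3-amino-5-fluorophenyl on an amide-type nitrogen in a ring as its only change. Within the data shown here, three measured steps touch that same aromatic group: a step that the two limits leave unreadable from compound 1 to compound 2 and a step that the two limits leave unreadable from compound 1 to compound 3 and a step that the two limits leave unreadable from compound 2 to compound 3 all stay without a readable size. Among the measured compounds shown here, no compound with a nitrile has been measured yet. Compound 3 stays at the limit across a step that the two limits leave unreadable from compound 1 to compound 3 so no step beyond the scatter is expected in either direction. The estimated change is a step that the limit leaves unreadable from compound 3 to compound 4 and it has no clear direction. For compound 4 the expected value in this assay is 20000 nM with an estimated range from 8000 nM to 50000 nM and most likely a report as a limit again.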

Compound 4, half-maximal cytotoxic concentration: > 10000 nM
Compound 4: no number, only a limit (the forecaster's own chance of this, stated with the estimate: 90%); the middle value is on the limit's open side.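

The steps from compound 1, compound 2 and compound 3 to compound 4 cannot be read, because all four compounds give a limit and not a number: the limit of > 10000 nM in this assay, at which 4 of the 4 values shown sit.

In this assay the compounds shown leave open whether the aromatic group on the amide-type nitrogen changes the read-out at all, and how the four would rank.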